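The source may report more compounds than this note shows. Statements on the series, on what has been measured and on what is new or still open speak of the compounds shown alone.

Series notes. Compound 1 `CC#CCn1c(N2CCC[C@@H](N)C2)cc(=O)n(Cc2ccc(Cl)c(C(=O)O)c2)c1=O` is the reference point in an assay on isolated protein for inhibition of Dipeptidyl peptidase 9 (Homo sapiens), read by fluorescence, with stated times of 15 min and 20 min; a lower number here means a stronger inhibitor, a higher number a weaker inhibitor. In this assay compound 1 returns only a limit, > 100 nM, not a number. Compound 2 `CC#CCn1c(N2CCC[C@@H](N)C2)cc(=O)n(Cc2cccc(C(=O)OC)c2F)c1=O` and compound 3 `CC#CCn1c(N2CCC[C@@H](N)C2)cc(=O)n(Cc2cc(C(=O)OC)ccc2F)c1=O` share the core of compound 1 with differently substituted benzyl groups. In this assay compound 2 likewise returns a limit, > 100 nM. In this assay compound 3 too returns a limit, > 100 nM. Compound 1 therefore stands at the limit of > 100 nM in this assay, at which 3 of the 3 values shown sit; no measured step separates any two of these compounds, and none can be ranked against another.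

Compound 4 `CC#CCn1c(N2CCC[C@@H](N)C2)cc(=O)n(Cc2ccc(Br)c(C(=O)O)c2)c1=O` differs from compound 1 by bromo in place of chloro on an aromatic carbon: chloro leaves, bromo enters, and cut one bond further out the difference reads 3-carboxy-4-chlorophenyl to 4-bromo-3-carboxyphenyl. Going by the values given here, no measured pair bears on this exchange. The step from compound 1 to compound 4 in this assay is expected to be none beyond the scatter, a step that the limit leaves unreadable from compound 1 to compound 4. Compound 4 is expected to give 300 nM in this assay, between 100 nM and 3000 nM, and most probably to be reported again only as a limit.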

Compound 4, half-maximal inhibitory concentration: > 100 nM
Compound 4 gave a limit, no number; the forecaster's own chance of this, stated with the estimate: 85%; the middle value does not contradict the limit.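

Compound 4, like compound 1, returns only a limit, so no step can be read between them: the limit of > 100 nM in this assay, at which 4 of the 4 values shown sit.

The compounds shown leave open whether bromo in place of chloro changes inhibition at all, and how the four compounds rank in this assay.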